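Dropping the Methoxy Between Compound 1 and Compound 4

The source may report more compounds than this note shows. Statements on the series, on what has been measured and on what is new or still open speak of the compounds shown alone.

Compound 1, `COc1cccc(CC2CCCCN2C(=O)n2ncc(C(O)(c3ccc(F)cc3)c3ccc(F)cc3)n2)c1`, gives 158 nM in an assay on isolated protein for inhibition of Monoacylglycerol lipase ABHD6 (Homo sapiens), read by fluorescence (a lower number here means a stronger inhibitor, a higher number a weaker inhibitor), the lowest of the three numbers recorded there. Compound 3, `O=C(N1C[C@@H](O)C=C[C@@H]1Cc1ccccc1)n1ncc(C(O)(c2ccc(F)cc2)c2ccc(F)cc2)n1`, gives 251 nM, a difference that stays within the scatter of this assay, so the two cannot be told apart. Compound 2, `O=C(N1CCCCC1Cc1ccccc1)n1ncc(C(O)(c2ccccn2)c2ccccn2)n1`, gives 3160 nM, a gap to compound 1 that lies beyond the scatter.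

Compound 4, `O=C(N1CCCCC1Cc1ccccc1)n1ncc(C(O)(c2ccc(F)cc2)c2ccc(F)cc2)n1`, differs from compound 1 in one place: hydrogen in place of methoxy on an aromatic carbon. Among the compounds with values here, with no measured pair showing this change, the step is expected to be small, likely none beyond the scatter, in either direction. The expected step in this assay is a 1.4-fold higher number from compound 1 to compound 4 (0.14 log units; within the scatter). Compound 4 is estimated at 220 nM, within a range from 80 nM to 600 nM.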

Compound 4, half-maximal inhibitory concentration: 25.1 nM
Beside the measured number, compound 4's estimate is 8.8-fold (0.94 log units) above it, outside the stated range (below it).
By their numbers in this assay, from the lowest: compound 4; then compounds 1 and 3 (each within the scatter of the next); then compound 2.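

Taking the methoxy off the 3-methoxybenzyl group gives a 6.3-fold lower number from compound 1 to compound 4 (0.80 log units; beyond the scatter) in this assay. Within the data shown here, this shows that the position on this aromatic ring is not neutral and that, of the two, hydrogen gives the stronger inhibitor, which no earlier pair could show. Nothing at hand explains the size or direction of this step.

As far as these compounds go, it remains open whether the drop in strength is specific to methoxy, since a fluorine, a hydroxyl or an amine at this ring carbon could separate methoxy from other groups. From the compounds shown here alone, it is also open whether the same step would hold on the core of compound 3.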